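A few compounds are considered here, and "the series" means these few. Any claim that something is new, unique, unknown or untested is made for them only; others in the source may bear on it.

Values in a toxicity assay on Vero cells (Chlorocebus sabaeus) for cytotoxicity, read by MTT assay (on this read-out lower numbers stand for stronger inhibition and higher numbers for weaker inhibition), so far:
- compound 1 `COC(=O)NC(=O)c1ccsc1NC(=O)c1ccc(S(=O)(=O)N2CCC2)cc1` gives 17.5 ug/mL as a measured number
- compound 2 `COC(=O)NC(=O)c1ccsc1NC(=O)c1ccc(S(=O)(=O)NC2CCC(F)(F)CC2)cc1` gives 49 ug/mL as a measured number
- compound 3 `CCOC(=O)NC(=O)c1ccsc1NC(=O)c1ccc(S(=O)(=O)N2CCC2)cc1` gives > 64 ug/mL as a limit of the assay

Compound 3 stands at the limit of > 64 ug/mL in this assay, at which 1 of the 3 values shown sits, and so offers no number to step from. Next is compound 4 `CCOC(=O)NC(=O)c1ccsc1NC(=O)c1ccc(S(=O)(=O)Nc2ccc(F)cc2)cc1` which carries (4-fluorophenyl)amino in place of azetidin-1-yl on a sulfonyl sulfur relative to compound 3. The nearest measured change in that place is a 2.8-fold higher number from compound 1 to compound 2 (0.45 log units; beyond the scatter) and it points upward, though the group entering there is not aromatic. The other measured change (an at least 3.6-fold higher number from compound 1 to compound 3 (0.56 log units; beyond the scatter)) is already contained in compound 3 and is kept in compound 4. With one loose precedent and a starting point that is a limit, no step beyond the scatter is expected in this assay and another limit reading is about as likely as a number. The expected step is an at least 1.0-fold lower number from compound 3 to compound 4 (0.02 log units; that floor lies within the scatter) on this estimate. For compound 4 the estimated value is 60 ug/mL with an expected range from 25 ug/mL to 128 ug/mL as working bounds.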

Compound 4, half-maximal inhibitory concentration: 20.5 ug/mL
Compound 4: the middle estimate sits 2.9-fold (0.47 log units) above what was measured; measured number outside the range, below it.
By their numbers in this assay, from the lowest: compounds 1 and 4 (each within the scatter of the next); then compound 2. At a limit, above all of these: compound 3.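

In this assay, the sulfonyl sulfur tolerates a change that lowers the number: (4-fluorophenyl)amino in place of azetidin-1-yl gives an at least 3.1-fold lower number from compound 3 to compound 4 (0.49 log units; beyond the scatter). The earlier change at this place, with (4,4-difluorocyclohexyl)amino entering, ran the other way, a 2.8-fold higher number from compound 1 to compound 2 (0.45 log units; beyond the scatter), so the direction of a step here is not fixed by the place alone, although the two steps start from compounds that differ by a methyl on the chain. Compound 3 stands at a limit, so the new step has a floor and no exact size: the limit of > 64 ug/mL in this assay, at which 1 of the 4 values shown sits.

Open, going by these compounds, is whether the aromatic ring or the fluorine carries the step, a question that an unsubstituted phenylamino group on the sulfonyl sulfur would address. Also open, on these data alone, is whether (4-fluorophenyl)amino gives a step of the same direction on the core of compound 1.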